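Two Stereo Elements Reversed on Compound 3

The source may hold more compounds than are shown below. What is called first, only, known or untested is meant among the compounds shown, and "the series" means these compounds.

The set holds compound 1 `Nc1nc2c(ncn2/C=C2/C[C@H]2[C@@H](O)CO)c(=O)[nH]1`, compound 2 `Nc1ncnc2c1ncn2/C=C1/C[C@H]1[C@H](O)CO`, compound 3 `Nc1ncnc2c1ncn2/C=C1\C[C@@H]1[C@@H](O)CO` and the still unmeasured compound 4 `Nc1ncnc2c1ncn2/C=C1/C[C@H]1[C@@H](O)CO`. In an ADME assay on HFF cells (Homo sapiens) for cytotoxicity, read by neutral red uptake (on this read-out higher numbers stand for lower toxicity in this test and lower numbers for higher toxicity in this test), compound 1 gives 299000 nM. In this assay compound 2 gives 206000 nM. For compound 3 this assay reports only a limit, > 300000 nM, and no number. So compound 3 stands at the top of the shown values, known only as a limit.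

Compound 4 differs from compound 3 as follows: the two compounds have the same atoms and bonds and differ only in configuration as drawn: 2 of 3 stereo elements differ; a stereocentre at a saturated ring carbon is drawn S in compound 3 and R in compound 4; a double bond is drawn E in compound 3 and Z in compound 4. For the measured compounds named here, the one measured step that bears on such a change is an at least 1.4-fold higher number from compound 2 to compound 3 (0.16 log units; that floor lies within the scatter), which rests on the fact that compounds 2 and 3 differ only in the configuration as drawn and whose floor comes from the limit of > 300000 nM in this assay, at which 1 of the 3 values shown sits; it stayed within the scatter.

Because that configurational step an at least 1.4-fold higher number from compound 2 to compound 3 (0.16 log units; that floor lies within the scatter) stayed within the scatter, compound 4 is expected to show an at least 1.0-fold lower number from compound 3 to compound 4 (0.02 log units; that floor lies within the scatter), a step that does not go beyond the scatter. Compound 4 is estimated at 280000 nM, with a range from 150000 nM to 600000 nM, and it may again be reported only as a limit.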

Compound 4, half-maximal cytotoxic concentration: 194000 nM
Compound 4: middle estimate off by 1.4-fold (0.16 log units), on the high side; the range from low to high includes it.
By their numbers in this assay, from the lowest: compounds 4, 2 and 1 (each within the scatter of the next). At a limit, above all of these: compound 3.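

In this assay, for the compounds shown here, a change at the saturated chain carbon alone, with the ring carbon and the double bond as drawn unchanged, gives a 1.1-fold lower number from compound 2 to compound 4 (0.03 log units; within the scatter), which isolates this one stereo element for the first time and stays within the scatter. Changing the saturated ring carbon and the double bond together gives an at least 1.5-fold lower number from compound 3 to compound 4 (0.18 log units; that floor lies within the scatter), a floor that also lies within the scatter, whereas the earlier step had changed all three elements at once. Compound 3 is still known only as a limit, > 300000 nM, so the full size of its steps cannot be read.

No pair shown changes the ring carbon or the double bond alone, so their separate contributions stay open. The compounds shown also do not tell how a carboxylic acid or a longer chain in place of the chain would read in this assay.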